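Chloro in Place of Methyl on Compound 1

The source may hold more compounds than are shown below. What is called first, only, known or untested is meant among the compounds shown, and "the series" means these compounds.

In a functional assay on A549 cells (Homo sapiens) for antiproliferative activity, read by CCK-8 assay, with a stated time of 72 h (on this read-out lower numbers stand for stronger inhibition and higher numbers for weaker inhibition), compound 1 `CC1=NN(c2ccc(C)cc2)C(=O)C12C=CC(=O)C=C2c1ccc(C)cc1` gives 37000 nM. Compound 2 `CC1=NN(c2ccc(C)cc2)C(=O)C12C=CC(=O)C=C2c1ccccc1` gives 46300 nM, and the step of a 1.3-fold higher number from compound 1 to compound 2 (0.10 log units; within the scatter) shows the two numbers sit within the scatter of each other. Compound 3 `CC1=NN(c2ccc(Br)cc2)C(=O)C12C=CC(=O)C=C2c1ccccc1` reaches only the limit of this assay, > 100000 nM. Compound 4 `CC1=NN(c2ccc(Cl)cc2)C(=O)C12C=CC(=O)C=C2c1ccc(C)cc1` differs from compound 1 by chloro in place of methyl on an aromatic carbon. Going by the values given here, the one step that bears on this kind of change, bromo in place of methyl, is an at least 2.1-fold higher number from compound 2 to compound 3 (0.33 log units; beyond the scatter), a weakening. A similar weakening is expected here, so compound 4 is estimated at 80000 nM, between 40000 nM and 200000 nM, a step of a 2.2-fold higher number from compound 1 to compound 4 (0.33 log units; beyond the scatter) that may again end at a limit, as the limit of > 100000 nM in this assay, at which 1 of the 3 values shown sits, shows.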

Compound 4, half-maximal inhibitory concentration: 33400 nM
Estimate against measurement, compound 4: 2.4-fold (0.38 log units) above; measured number below the stated range.
By their numbers in this assay, from the lowest: compounds 4, 1 and 2 (each within the scatter of the next). At a limit, above all of these: compound 3.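

In this assay, chloro in place of methyl at this position brings no readable change (a 1.1-fold lower number from compound 1 to compound 4 (0.04 log units; within the scatter)). A halogen here therefore need not weaken a compound, and the weakening seen with bromo (an at least 2.1-fold higher number from compound 2 to compound 3 (0.33 log units; beyond the scatter)) does not carry over to chloro. Going by these compounds alone, compound 3 remains the one compound that goes against this, and its value is a limit: the limit of > 100000 nM in this assay, at which 1 of the 4 values shown sits.

Still open, on these data alone, is whether an amine, a carboxylic acid or a longer chain at this position would bring the number down. As far as these compounds go, whether chloro would behave the same way on the other aromatic ring also remains unknown.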